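Moving the chlorine on the amide-side pyridine

The compounds below may be only part of what the source reports. "The series", "measured", "known", "first", "only" and "open" are said of these compounds alone.

Of the compounds shown here, three sharing one core have been measured in a functional assay on LoVo cells (Homo sapiens) for inhibition, read by MTT assay, with a stated time of 72 h; a higher number here means a weaker inhibitor, a lower number a stronger inhibitor. Compound 1 `Cn1cc(-c2cnc(N)c(Oc3ccc(C(=O)Nc4ccccc4Cl)cc3)n2)cn1` gives 41400 nM, compound 2 `Cn1cc(-c2cnc(N)c(Oc3ccc(C(=O)Nc4ccc(Cl)cc4)cc3)n2)cn1` gives 3080 nM, and compound 3 `Cn1cc(-c2cnc(N)c(Oc3ccc(C(=O)Nc4ccc(Cl)cn4)cc3)n2)cn1` gives 6160 nM. Among these three numbers compound 3 stands second highest; it sits close to compound 2 and far from compound 1, since a 2.0-fold higher number from compound 2 to compound 3 (0.30 log units; within the scatter) while a 6.7-fold lower number from compound 1 to compound 3 (0.83 log units; beyond the scatter).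

Compound 4 `Cn1cc(-c2cnc(N)c(Oc3ccc(C(=O)Nc4ncccc4Cl)cc3)n2)cn1` differs from compound 3 only in the amide-side ring: 3-chloropyridin-2-yl in place of 5-chloropyridin-2-yl on an amide-type nitrogen. Going by the values given here, no measured pair shows exactly this change, but the phenyl series offers a parallel, because a 13-fold lower number from compound 1 to compound 2 (1.13 log units; beyond the scatter), which describes the chlorine shifting from the 2-position to the 4-position of the phenyl. The step from compound 3 to compound 4 runs the other way on a pyridine, carrying the chlorine from the 5-position back to the 3-position. If the pyridine behaves like the phenyl, a large rise in this assay is expected, on the order of the reverse of that phenyl step. Compound 4 is therefore estimated at 40000 nM, with a range of 10000 nM to 150000 nM, a step of a 6.5-fold higher number from compound 3 to compound 4 (0.81 log units; beyond the scatter) expected, with some chance that only a limit is reported.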

Compound 4, half-maximal inhibitory concentration: 16500 nM
Estimate against measurement, compound 4: 2.4-fold (0.38 log units) above; low and high end bracket the measured number.
By their numbers in this assay, from the lowest: compounds 2 and 3 (each within the scatter of the next); then compound 4; then compound 1.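

Compound 4 and compound 3 hold the same atoms joined differently, and that change alone gives a 2.7-fold higher number from compound 3 to compound 4 (0.43 log units; beyond the scatter) in this assay, so the placing of the chlorine counts on the pyridine as well as on the phenyl. The sense matches the phenyl pair, where 2-chlorophenyl also carries the higher number, but the pyridine step is the smaller of the two, the phenyl one reading a 13-fold lower number from compound 1 to compound 2 (1.13 log units; beyond the scatter). Exchanging phenyl for pyridine is also not neutral throughout: a 2.0-fold higher number from compound 2 to compound 3 (0.30 log units; within the scatter) stays within the scatter, whereas a 5.4-fold higher number from compound 2 to compound 4 (0.73 log units; beyond the scatter) and a 2.5-fold lower number from compound 1 to compound 4 (0.40 log units; beyond the scatter) lie beyond it, which places 3-chloropyridin-2-yl between the two chlorophenyl groups in this assay, and nothing shown here offers a measured reason for any of these steps.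

On these data alone, every amide-side ring in these four compounds carries a chlorine, so it remains open how a fluorine, a methoxy group or a ring with no substituent would read at this position. All four numbers also come from this assay alone, which leaves open whether the same order would hold in any other cell line or assay.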